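Shifting the thiophene attachment point on a dihydropyrimidinone core

The source may report more compounds than this note shows. Statements on the series, on what has been measured and on what is new or still open speak of the compounds shown alone.

Measured so far:
- compound 1 `CCCOC(=O)C1=C(C)NC(=O)NC1c1ccsc1`: 6%
- compound 2 `CC1=C(C(=O)OC(C)(C)C)C(c2ccsc2)NC(=O)N1`: 1%
- compound 3 `CC1=C(C(=O)C2CC2)C(c2cccs2)NC(=O)N1`: 15%

Of the compounds shown here, three built on the shared core have been tested in an assay on membranes from HeLa cells for displacement of a labelled ligand from adenosine receptor A3 (Homo sapiens), read by scintillation counting, with a stated time of 180 min, tested at 1 uM; on this read-out higher numbers stand for more inhibition at the one concentration tested (going by the name of the read-out) and lower numbers for less inhibition. Compound 3 gives the highest of the three numbers, with compound 1 the nearest to it and compound 2 the furthest, and only the gap to compound 2 lies beyond the usual scatter. Within the data shown here, the one measured step, a number 5 percentage points lower from compound 1 to compound 2 (within the scatter), concerns an ester group and stays within the scatter.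

Compound 4 `CC1=C(C(=O)C2CC2)C(c2ccsc2)NC(=O)N1` is not yet measured. It differs from compound 3 in one place: thiophen-3-yl in place of thiophen-2-yl on a saturated ring carbon. Among the measured compounds shown here, no measured step bears directly on this change; compounds 1 and 2 carry thiophen-3-yl but also differ from compound 3 in the cyclopropylcarbonyl group, so their values only hint at what thiophen-3-yl brings. Given that, and that all three numbers are low, the expected step of a number 5 percentage points lower from compound 3 to compound 4 (within the scatter) is small and without a direction beyond the scatter. Compound 4 is therefore estimated at 10%, with a range from 0% to 22%.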

Compound 4, a percentage reported as inhibition, at one concentration (the size of the read-out at that concentration, not a potency): 1%
Compound 4: middle estimate off by 9 percentage points, on the high side; the range from low to high includes it.
By their numbers in this assay, from the lowest: compounds 2, 4, 1 and 3 (each within the scatter of the next, the first and the last beyond it).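

Swapping thiophen-2-yl for thiophen-3-yl on the saturated ring carbon, with the rest of the molecule unchanged, gives in this assay the first measured single change that exceeds the scatter: a number 14 percentage points lower from compound 3 to compound 4 (beyond the scatter) and so, although the two groups have the same atoms, the attachment point of the thiophene counts in this pair. With thiophen-3-yl held in place, cyclopropyl in place of tert-butoxy gives no change at the digits printed from compound 2 to compound 4 (within the scatter) and cyclopropyl in place of propoxy gives a number 5 percentage points lower from compound 1 to compound 4 (within the scatter) so neither swap on the carbonyl carbon moves the number beyond the scatter.

From the compounds shown here alone, whether thiophen-2-yl would also give the higher number alongside a propyl ester, and what a phenyl ring or a furan ring would give at this carbon, remains open. Nothing shown explains why the attachment point matters.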